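This account rests on a few compounds, and the source may have more. Where it says the series, first, only, none or still open, it means among the compounds named here.

Two compounds of the series carry a number in a functional assay on the whole organism for inhibition of sodium-dependent dopamine transporter (Mus musculus); a higher number here means that more compound is needed for the effect, a lower number that less compound is needed. Compound 1 `Cc1ccc(C2CN(C)Cc3c(N)cccc32)cc1` gives about 22 mg/kg. Compound 2 `CCNCC(=O)Nc1cccc2c1CN(C)CC2c1ccc(Cl)cc1` gives about 25 mg/kg in this assay, the higher of the two numbers, although the gap to compound 1 lies within the scatter, so the two cannot be told apart on these numbers. Compound 3 `CCNCC(=O)Nc1cccc2c1CN(C)CC2c1ccc(C)cc1` has not been measured. It differs from compound 2 by methyl in place of chloro on an aromatic carbon, para to a large group, so that 4-chlorophenyl becomes 4-methylphenyl. Going by the values given here, no measured pair in this assay shows this exchange on its own. The nearest guide is that compound 1, carrying the 4-methylphenyl with about 22 mg/kg, and compound 2, carrying the 4-chlorophenyl with about 25 mg/kg, stand within the scatter of each other in this assay, though they also differ elsewhere on the shared core. The step from compound 2 to compound 3 is expected to be small, a 1.1-fold lower number from compound 2 to compound 3 (0.06 log units; within the scatter), with no direction beyond the scatter. For compound 3 the expected dose for half-maximal effect is 22 mg/kg, in the range 10 mg/kg to 48 mg/kg.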

Compound 3, dose for half-maximal effect: about 15 mg/kg
Beside the measured number, compound 3's estimate is 1.5-fold (0.17 log units) above it, within the range that was stated.
By their numbers in this assay, from the lowest: compounds 3, 1 and 2 (each within the scatter of the next).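

In this assay, the exchange of 4-chlorophenyl for 4-methylphenyl now stands as a pair differing in one place, and a 1.7-fold lower number from compound 2 to compound 3 (0.22 log units; within the scatter) does not separate methyl from chloro on this aromatic carbon, para to a large group. The second pair adds a look at the nitrogen on the aromatic ring: with 4-methylphenyl held constant, ((ethylamino)methyl)carbonyl in place of hydrogen gives a 1.5-fold lower number from compound 1 to compound 3 (0.17 log units; within the scatter), so the two forms cannot be told apart on these numbers in this assay. Nothing available here accounts for the size of either step.

The compounds shown cover only methyl and chloro at the aromatic carbon, so it remains open whether a methoxy group, a trifluoromethyl group or a carboxylic acid there would give a step beyond the scatter. On the nitrogen, only hydrogen and ((ethylamino)methyl)carbonyl appear, which leaves open whether a longer chain in place of the ethyl group, or a cyclic amine in place of the ethylamino group, would separate from compound 3 in this assay.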